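A few compounds are considered here, and "the series" means these few. Any claim that something is new, unique, unknown or untested is made for them only; others in the source may bear on it.

Series notes. In a functional assay on A549 cells (Homo sapiens) for cytotoxicity, read by MTT assay, with a stated time of 72 h (on this read-out lower numbers stand for stronger inhibition and higher numbers for weaker inhibition), compound 1 `Cc1c(C(=O)Nc2ccc(Oc3ccnc4[nH]ccc34)c(F)c2)nnn1-c1ccc(F)c(F)c1` gives 570 nM. Compound 2 `Cc1c(C(=O)Nc2ccc(Oc3ccnc4[nH]ccc34)cc2)nnn1-c1ccccc1F` gives 320 nM in this assay. Compound 2 carries the lower of the two numbers, but its gap to compound 1 lies within the scatter, so the two values are read as alike. Among the measured compounds shown here, compound 1 and compound 2 differ in two places, so no single step between them is drawn. Compound 3 `Cc1c(C(=O)Nc2ccc(Oc3ccnc4[nH]ccc34)cc2)nnn1-c1ccc(F)c(F)c1` is the next entry for this assay. The change from compound 2 is 3,4-difluorophenyl in place of 2-fluorophenyl on an aromatic nitrogen. Compound 1, which carries the same 3,4-difluorophenyl on the shared core, gives 570 nM and sits within the scatter of compound 2, so no step beyond the scatter is expected here. The step from compound 2 to compound 3 is expected to be a 1.4-fold higher number from compound 2 to compound 3 (0.15 log units; within the scatter), in no firm direction. For compound 3 the estimate in this assay is 450 nM, with a range from 200 nM to 1000 nM.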

Compound 3, half-maximal inhibitory concentration: 2260 nM
For compound 3 the middle estimate is 5.0-fold (0.70 log units) below the measured one; the measured number lies above the stated range.
By their numbers in this assay, from the lowest: compounds 2 and 1 (each within the scatter of the next); then compound 3.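

On the aromatic nitrogen of the five-membered ring, 3,4-difluorophenyl in place of 2-fluorophenyl gives a 7.1-fold higher number from compound 2 to compound 3 (0.85 log units; beyond the scatter) in this assay, so this position does respond to the change of aryl group when the rest of the molecule stays fixed. With 3,4-difluorophenyl held constant, hydrogen in place of fluoro on an aromatic carbon gives a 4.0-fold higher number from compound 1 to compound 3 (0.60 log units; beyond the scatter), so the likeness of the values for compound 1 and compound 2 says nothing about either place taken alone. Nothing available explains either step.

A plain phenyl, or a phenyl bearing chloro or methoxy, on that nitrogen would help separate the effect of the 2-fluoro group from that of the 3,4-difluoro pattern. Going by these compounds, it also remains open whether the fluoro step on the aromatic carbon would recur with 2-fluorophenyl in place.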